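The source may hold more compounds than are shown below. What is called first, only, known or untested is meant among the compounds shown, and "the series" means these compounds.

Measured in a functional assay on CCRF-CEM cells (Homo sapiens) for antiproliferative activity, read by cell counting, with a stated time of 96 h; a lower number here means a stronger inhibitor, a higher number a weaker inhibitor:
- compound 1 `COc1ccc(Oc2ccccc2NC(C)=C2C(=O)CC(c3ccccc3)CC2=O)cc1` gives 120 nM
- compound 2 `CCOc1ccccc1NC(C)=C1C(=O)CC(c2ccccc2)CC1=O` gives 190 nM
- compound 3 `CC(Nc1ccccc1Oc1cccc(N)c1)=C1C(=O)CC(c2ccccc2)CC1=O` gives 42 nM

Compound 3 holds the lowest number of the three in this assay, and its steps to both others lie beyond the scatter. The next structure is compound 4 `COc1cccc(Oc2ccccc2NC(C)=C2C(=O)CC(c3ccccc3)CC2=O)c1`, with methoxy in place of amino on an aromatic carbon. Going by the values given here, no measured step makes this exact exchange. The closest evidence is a 2.9-fold lower number from compound 1 to compound 3 (0.46 log units; beyond the scatter), with 3-aminophenyl in place of 4-methoxyphenyl. Also relevant is a 4.5-fold lower number from compound 2 to compound 3 (0.66 log units; beyond the scatter), with 3-aminophenyl in place of ethyl. Both favour the compound bearing 3-aminophenyl, whereas a 1.6-fold higher number from compound 1 to compound 2 (0.20 log units; within the scatter) shows no separation between 4-methoxyphenyl and ethyl. Loss of the amino group is therefore expected to give a modest rise in the number, no larger than these steps. The expected change is a 2.1-fold higher number from compound 3 to compound 4 (0.33 log units; beyond the scatter). The estimate for compound 4 is 90 nM, with an expected range of 35 nM to 220 nM.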

Compound 4, half-maximal inhibitory concentration: 41 nM
Beside the measured number, compound 4's estimate is 2.2-fold (0.34 log units) above it; low and high end bracket the measured number.
By their numbers in this assay, from the lowest: compounds 4 and 3 (each within the scatter of the next); then compounds 1 and 2 (each within the scatter of the next).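

In this assay, the step with a 1.0-fold lower number from compound 3 to compound 4 (0.01 log units; within the scatter) shows that the amino group is not required at this aromatic carbon: methoxy, with 0 hydrogen-bond donors, stays within the scatter of amino here. The advantage of the 3-substituted phenoxy compounds therefore survives the exchange, with a 4.6-fold lower number from compound 2 to compound 4 (0.67 log units; beyond the scatter) for 3-methoxyphenyl in place of ethyl, and a 2.9-fold lower number from compound 1 to compound 4 (0.47 log units; beyond the scatter) for 3-methoxyphenyl in place of 4-methoxyphenyl, so the same methoxy group gives different numbers on the two ring positions. No accompanying measurement offers an explanation for these numbers.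

The compounds shown leave open what an unsubstituted phenyl on that oxygen would give. They also leave open how a hydroxyl or a carboxylic acid on the same aromatic carbon would compare with amino and methoxy.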